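Isobutyl to 3-methoxyphenyl on the aromatic nitrogen

This account rests on a few compounds, and the source may have more. Where it says the series, first, only, none or still open, it means among the compounds named here.

Of the compounds shown here, three have been measured in a functional assay on T47D cells (Homo sapiens) for antiproliferative activity, read by MTT assay, with a stated time of 72 h; on this read-out higher numbers stand for weaker inhibition and lower numbers for stronger inhibition. Compound 1 `CCCCn1ccnc1-c1cc(OC)c(OC)c(OC)c1` gives > 100000 nM, which is a limit. Compound 2 `COc1cc(-c2nccn2CC(C)C)cc(OC)c1OC` gives > 100000 nM, also a limit. That limit, (the limit of > 100000 nM in this assay, at which 2 of the 3 values shown sit), is all that is known of compound 2, so it has no number of its own. Going by the values given here, compound 3 `COc1cc(-c2nccn2-c2ccc3sccc3c2)cc(OC)c1OC` gives 17000 nM, the only true number so far.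

Compound 4 `COc1cccc(-n2ccnc2-c2cc(OC)c(OC)c(OC)c2)c1` differs from compound 2 by 3-methoxyphenyl in place of isobutyl on an aromatic nitrogen. Among the compounds with values here, the one measured step, a step that the two limits leave unreadable from compound 1 to compound 2, gives no size to carry over. The expectation rests instead on compound 3 at 17000 nM, which carries an aromatic ring on that nitrogen, as compound 4 does. Stronger inhibition is therefore expected in this assay, though the start is only a limit and another limit remains possible. The expected change is an at least 6.6-fold lower number from compound 2 to compound 4 (0.82 log units; beyond the scatter). For compound 4 the estimated value is 15000 nM, with an expected range of 3000 nM to 60000 nM.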

Compound 4, half-maximal inhibitory concentration: 32200 nM
Estimate against measurement, compound 4: 2.1-fold (0.33 log units) below; the range from low to high includes it.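

In this assay, 3-methoxyphenyl on this aromatic nitrogen gives a readable value where isobutyl and butyl do not, with an at least 3.1-fold lower number from compound 2 to compound 4 (0.49 log units; beyond the scatter) and an at least 3.1-fold lower number from compound 1 to compound 4 (0.49 log units; beyond the scatter). Each of these steps starts from a limit and so gives only a minimum size, and the step between compound 1 and compound 2 cannot be read, as both sit at the same limit: the limit of > 100000 nM in this assay, at which 2 of the 4 values shown sit. Compound 3 gives 17000 nM and compound 4 gives 32200 nM, so both compounds with an aromatic ring on this nitrogen give true numbers in this assay.

Going by these compounds, the true size of the change stays open while compound 1 and compound 2 are known only as limits. Also open, on these data alone, is what an unsubstituted phenyl, or a phenyl bearing an amine or a carboxylic acid, would give on this nitrogen.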